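The compounds below may be only part of what the source reports. "The series", "measured", "known", "first", "only" and "open" are said of these compounds alone.

Of the compounds shown here, two of a shared core have been measured in a functional assay on MDA-MB-231 cells (Homo sapiens) for cytotoxicity, read by MTT assay, with a stated time of 24 h; on this read-out higher numbers stand for weaker inhibition and lower numbers for stronger inhibition. Compound 1 `Cc1cc(O)c(C(=O)/C=C/c2ccc(Cl)cc2)c(-c2ccc(Br)cc2)c1C(=O)/C=C/c1ccc(Cl)cc1` gives 15000 nM in this assay, the highest of the two numbers. Compound 2 `Cc1cc(O)c(C(=O)/C=C/c2ccccc2)c(-c2ccc(Cl)cc2)c1C(=O)/C=C/c1ccccc1` gives 4400 nM in this assay, a lower number, and the gap between the two lies beyond the usual scatter. Compound 3 `Cc1cc(O)c(C(=O)/C=C/c2ccc(Cl)cc2)c(-c2ccc(Cl)cc2)c1C(=O)/C=C/c1ccc(Cl)cc1` has not yet been measured. It differs from compound 1 by a single change, (chloro in place of bromo on an aromatic carbon), chloro in place of bromo on an aromatic carbon. Within the data shown here, no measured pair shows the effect of this change on its own, so the direction has to be guessed from the swap itself, and a swap of one halogen for another of this kind is usually a small step. The expected step in this assay is a 1.5-fold lower number from compound 1 to compound 3 (0.18 log units; within the scatter), a modest move toward a lower number. Compound 3 is therefore estimated at 10000 nM, with a range from 4000 nM to 25000 nM.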

Compound 3, half-maximal inhibitory concentration: 30000 nM
Compound 3: middle estimate off by 3.0-fold (0.48 log units), on the low side, outside the stated range (above it).
By their numbers in this assay, from the lowest: compound 2; then compounds 1 and 3 (each within the scatter of the next).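

In this assay, among these compounds, the swap from 4-bromophenyl to 4-chlorophenyl gives a 2.0-fold higher number from compound 1 to compound 3 (0.30 log units; within the scatter), the first direct reading of this change at this position. The two halogens therefore cannot be told apart here: at the ring position para to a large group, this one-atom exchange leaves no difference larger than repeat measurements would produce. No measurement shown accounts for the values of these two compounds.

On these data alone, whether a different kind of group at this position, such as an amine, a carboxylic acid or a methoxy group, would move the number beyond the scatter remains open. Also open is whether the same halogen swap would give a similar step in the setting of compound 2, since its bromo counterpart is not among the compounds shown.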